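A Branched Chain on the Amide of Compound 2

This account rests on a few compounds, and the source may have more. Where it says the series, first, only, none or still open, it means among the compounds named here.

Of the compounds shown here, three sharing one core have been measured in a functional assay on QGY7701 cells (Homo sapiens) for cytotoxicity, read by MTT assay, with a stated time of 24 h; a lower number here means a stronger inhibitor, a higher number a weaker inhibitor. Compound 1, `C=CC1=C(C(=O)NCc2ccc(Cl)cc2)C(c2ccc(OC)c(OC)c2)OC1`, gives only a limit in this assay, > 100000 nM, which is a boundary of the measurement rather than a number (the limit of > 100000 nM in this assay, at which 1 of the 3 values shown sits). Compound 2, `C=CC1=C(C(=O)NCCC)C(c2ccc(Cl)c(Cl)c2)OC1`, gives 31300 nM, and compound 3, `C=CC1=C(C(=O)Nc2ccccc2)C(c2ccc(F)cc2)OC1`, gives 46700 nM. Of the two numbers shown, that of compound 2 is the smaller, but the gap to compound 3 lies within the scatter, so the two count as alike. Compound 4, `C=CC1=C(C(=O)NCC(C)C)C(c2ccc(Cl)c(Cl)c2)OC1`, differs from compound 2 by methyl in place of hydrogen on a saturated chain carbon bound to two saturated chain carbons. Among the compounds with values here, no measured pair isolates that change, so only a small step is expected, a 1.3-fold lower number from compound 2 to compound 4 (0.10 log units; within the scatter), no further than the scatter. Compound 4 is therefore expected near 25000 nM, between 10000 nM and 70000 nM.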

Compound 4, half-maximal inhibitory concentration: > 100000 nM
Compound 4 gave a limit, no number; the forecaster's own chance of this, stated with the estimate: 10%; middle value at least 4.0-fold (0.60 log units) from the limit.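

Methyl in place of hydrogen on a saturated chain carbon bound to two saturated chain carbons, which turns propyl into isobutyl, is not a silent change here: this assay shows an at least 3.1-fold higher number from compound 2 to compound 4 (0.50 log units; beyond the scatter). This single-place comparison shows that a one-carbon addition at this position can weaken the cytotoxic effect. Compound 4 gives > 100000 nM, which is a limit and not a number, so the full size of the step stays unknown: the limit of > 100000 nM in this assay, at which 2 of the 4 values shown sit.

From the compounds shown here alone, whether butyl, a longer chain without the branch, would behave like propyl or like isobutyl stays open. So does the effect of an amine in that chain.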